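The source may hold more compounds than are shown below. What is called first, only, known or untested is meant among the compounds shown, and "the series" means these compounds.

The series shares a single core carrying two substituted benzene rings, one through a carbonyl and one through an amine. Compound 1 `Cc1ccc(Nc2nc(N)c(C(=O)c3ccccc3)s2)cc1` gives 210 nM in a functional assay on MOLT-4 cells (Homo sapiens) for antiproliferative activity, read by cell counting, with a stated time of 2 days; a higher number here means a weaker inhibitor, a lower number a stronger inhibitor. Compound 2 `COc1ccc(Nc2nc(N)c(C(=O)c3cc(OC)c(OC)c(OC)c3)s2)cc1` gives 480 nM in this assay, and compound 3 `COc1ccc(Nc2nc(N)c(C(=O)c3ccc(OC)c(OC)c3)s2)cc1` gives 37 nM. Among these three numbers compound 1 stands second highest: compound 2 is its nearest neighbour with a higher number, and compound 3 is furthest with a clearly lower number. Going by the values given here, the one step known so far, a 13-fold lower number from compound 2 to compound 3 (1.11 log units; beyond the scatter), concerns the ring attached to the carbonyl, not the ring attached to the amine.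

Compound 4 `Nc1nc(Nc2ccc(Cl)cc2)sc1C(=O)c1ccccc1` differs from compound 1 in a single place: chloro in place of methyl on an aromatic carbon. Among the compounds with values here, no measured step touches this ring, so nothing in the data says how a chloro in place of a methyl on that aromatic carbon will read. Within the data shown here, with no step to lean on, the expectation for compound 4 is a number near that of compound 1, and the step of a 1.2-fold lower number from compound 1 to compound 4 (0.07 log units; within the scatter) is expected to stay within the usual scatter. Compound 4 is therefore estimated at 180 nM, with a range from 60 nM to 550 nM.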

Compound 4, half-maximal inhibitory concentration: > 10000 nM
Compound 4 was reported as a limit (the forecaster's own chance of this, stated with the estimate: 3%); at least 55-fold (1.74 log units) between middle value and limit.
By their numbers in this assay, from the lowest: compound 3; then compound 1; then compound 2. At a limit, above all of these: compound 4.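

Going by these compounds alone, the ring attached to the amine, which no earlier step touched, now turns out to matter greatly in this assay: chloro in place of methyl, on an aromatic carbon para to a large group, gives an at least 47-fold higher number from compound 1 to compound 4 (1.67 log units; beyond the scatter). This swap exchanges one heavy atom for one heavy atom and leaves the counted hydrogen-bond donors, hydrogen-bond acceptors and net charge unchanged, and the earlier step, a 13-fold lower number from compound 2 to compound 3 (1.11 log units; beyond the scatter), lay on the ring attached to the carbonyl, so a large step is now seen on each of the two rings. The reading for compound 4 is a limit and not a number, so the full size of this step cannot be given: the limit of > 10000 nM in this assay, at which 1 of the 4 values shown sits.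

The compounds shown leave open whether a fluoro, a bromo or a plain hydrogen on this aromatic carbon would read like the methyl of compound 1 or like the chloro of compound 4. They also leave open whether chloro at this place would give the same result in a compound carrying the ring attached to the carbonyl of compound 3.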